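The source may hold more compounds than are shown below. What is called first, only, known or untested is meant among the compounds shown, and "the series" means these compounds.

Measured so far:
- compound 1 `S=C(NNc1nncc2ccccc12)Nc1ccccc1`: 45 nM
- compound 2 `Clc1ccc(C(/C=C/c2ccccc2)=N\Nc2nncc3ccccc23)cc1`: 4.6 nM

In a functional assay on DU-145 cells (Homo sapiens) for antiproliferative activity, read by sulforhodamine B assay, with a stated time of 72 h (on this read-out higher numbers stand for weaker inhibition and lower numbers for stronger inhibition), compound 1 gives 45 nM, the higher of the two numbers. Compound 2 gives 4.6 nM, and the gap between them lies beyond the scatter.

Compound 3 `COc1ccc(NC(=S)NNc2nncc3ccccc23)cc1` has methoxy in place of hydrogen on an aromatic carbon of compound 1, para to a large group: methoxy in place of hydrogen on an aromatic carbon. Among the measured compounds shown here, no measured pair shows this change, so the data give no direct guide. A step within the scatter is expected in this assay, with no firm direction.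

The expected step is a 1.1-fold lower number from compound 1 to compound 3 (0.05 log units; within the scatter). Compound 3 is estimated at 40 nM, with an expected range of 12 nM to 130 nM.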

Compound 3, half-maximal inhibitory concentration: 25 nM
Beside the measured number, compound 3's estimate is 1.6-fold (0.20 log units) above it; the range from low to high includes it.
By their numbers in this assay, from the lowest: compound 2; then compounds 3 and 1 (each within the scatter of the next).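

In this assay, methoxy in place of hydrogen on an aromatic carbon, para to a large group, gives a step within the scatter (a 1.8-fold lower number from compound 1 to compound 3 (0.26 log units; within the scatter)). Among the compounds shown here, this position therefore takes methoxy without a clear loss or gain, which the earlier compounds could not show. No measured property speaks to the origin of this step.

Going by these compounds, an amine or a carboxylic acid at this same place remains open. So does whether a longer chain on the oxygen would keep the number within the scatter of compound 1.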